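The compounds below may be only part of what the source reports. "The series", "measured", "known", "first", "only" and "open" are said of these compounds alone.

Measured compounds:
compound 1 `COc1ccccc1-n1cc2nc(-c3ccc(C)o3)nc(N)c2n1`, 1%
compound 2 `Cn1cc2nc(CCCc3ccccc3)nc(N)c2n1`, 36%
compound 3 `Nc1nc(Cc2ccccc2)nc2cn(Cc3ccccc3)nc12`, 1%

In an assay on CHO cells for displacement of a labelled ligand from adenosine receptor A1 (Homo sapiens), read by scintillation counting, with a stated time of 120 min, tested at 1 uM (on this read-out higher numbers stand for more inhibition at the one concentration tested (going by the name of the read-out) and lower numbers for less inhibition), compound 2 gives the highest of the three numbers, and both other compounds lie beyond the scatter below it. Compound 4 `Nc1nc(CCCc2ccccc2)nc2cn(-c3ccccc3F)nc12` is not yet measured. It differs from compound 2 in one place: 2-fluorophenyl in place of methyl on an aromatic nitrogen. For the measured compounds named here, no pair of measured compounds differs in just one place, so the size of this step has to be guessed. The two measured compounds carrying larger groups, compound 1 with 1% and compound 3 with 1%, sit far below compound 2, so a fall beyond the scatter is expected, a number 26 percentage points lower from compound 2 to compound 4 (beyond the scatter). Compound 4 is therefore estimated at 10%, within 0% to 30%.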

Compound 4, a percentage reported as inhibition, at one concentration (the size of the read-out at that concentration, not a potency): 25%
Estimate against measurement, compound 4: 15 percentage points below, and the stated range covers the measured number.
By their numbers in this assay, from the lowest: compounds 1 and 3 (each within the scatter of the next); then compound 4; then compound 2.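

With the rest of the molecule unchanged, placing 2-fluorophenyl in place of methyl on the aromatic nitrogen in this assay gives a number 11 percentage points lower from compound 2 to compound 4 (beyond the scatter). For the compounds shown here, this is the first single-place reading at this position: the step is beyond the scatter but modest, even though the entering group brings 7 heavy atoms and a six-membered aromatic ring. No measured evidence explains this step.

The compounds shown do not separate the contribution of the fluorine from that of the phenyl ring. Going by these compounds, how an unsubstituted phenyl, an amine or a longer chain on this nitrogen would read remains open.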